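Moving the lactam ring: expected cytotoxicity of compound 4

A few compounds are considered here, and "the series" means these few. Any claim that something is new, unique, unknown or untested is made for them only; others in the source may bear on it.

Three compounds have been measured in a functional assay on A549 cells (Homo sapiens) for cytotoxicity; a lower number here means that less compound is needed, a higher number that more compound is needed for the effect:
Compound 1 `CC1=C(O)[C@H](C/C(C)=C\CC[C@H](C)/C=C/C=C(\C)CCCC2=CCN(CCC(C)C)C2=O)OC1=O` gives 15.1 ug/mL.
Compound 2 `CCC(C)CN1CC=C(CCC/C(C)=C/C=C/[C@@H](C)CC/C=C(/C)C[C@@H]2OC(=O)C(C)=C2O)C1=O` gives 19 ug/mL.
Compound 3 `CCC(C)CN1CC=C(CCC/C(C)=C/C=C/[C@@H](C)CC/C=C(/C)C[C@H]2OC(=O)C(C)=C2O)C1=O` gives 27.1 ug/mL.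

Compound 2 holds the second highest of the three numbers. Its nearest neighbour is compound 1, with a 1.3-fold higher number from compound 1 to compound 2 (0.10 log units; within the scatter), and its furthest is compound 3, with a 1.4-fold higher number from compound 2 to compound 3 (0.15 log units; within the scatter); both of these steps stay within the scatter. The second step rests on (the fact that one of compounds 2 and 3 is drawn with a defined configuration and the other without, at the place where they differ), so it is not a clean comparison of two defined configurations.

Compound 4 `CC1=C(O)[C@H](C/C(C)=C\CC[C@H](C)/C=C/C=C(\C)CCCC2=CC(=O)N(CCC(C)C)C2)OC1=O` keeps every atom of compound 2 but joins them differently: a group of 11 heavy atoms (9 carbon, 1 nitrogen, 1 oxygen; one five-membered non-aromatic ring with 1 hetero atom) in place of a group of 11 heavy atoms (9 carbon, 1 nitrogen, 1 oxygen; one five-membered non-aromatic ring with 1 hetero atom), on a saturated chain carbon, three bonds along the chain from a double-bonded chain carbon. Going by the values given here, no measured step changes this part of the molecule in this way, so the two steps above are the only guide. They show that altering the group on the lactam nitrogen, or the drawing of one stereocentre, moves this assay no further than its scatter. On that basis the step of no change at the digits printed from compound 2 to compound 4 (within the scatter) is expected to stay within the scatter as well, with no clear direction. Compound 4 is therefore estimated at 19 ug/mL, within a range from 8 ug/mL to 45 ug/mL.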

Compound 4, concentration for half-maximal effect: 30 ug/mL
The estimate for compound 4 lay 1.6-fold (0.20 log units) below the measured number, within the range that was stated.
By their numbers in this assay, from the lowest: compounds 1, 2, 3 and 4 (each within the scatter of the next).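

Going by these compounds alone, compound 4 is the first compound here in which the five-membered non-aromatic ring with 1 hetero atom is itself joined differently, rather than a group on it or a drawn stereocentre being altered; the place is a saturated chain carbon, three bonds along the chain from a double-bonded chain carbon. In this assay, with the ring's atoms and its counts of double bonds, donors and acceptors all staying the same, this change gives a 1.6-fold higher number from compound 2 to compound 4 (0.20 log units; within the scatter) and a 2.0-fold higher number from compound 1 to compound 4 (0.30 log units; within the scatter), so at this place the two ways of joining the ring cannot be told apart by this read-out. The data at hand offer no explanation for this result.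

What a carboxylic acid, a simple amine or a longer chain would do in place of this ring stays open, since every compound shown carries a five-membered ring with the same atoms at this place. All the compounds shown also lie within the scatter of the next in the order of their numbers, so which part of the molecule, if any, governs the number is still unknown.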